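The compounds below may be only part of what the source reports. "The series", "measured", "known", "first", "only" and "open" are said of these compounds alone.

Three members of the series have been run in a functional assay on ECa-109 cells (Homo sapiens) for cytotoxicity, read by MTT assay, with a stated time of 48 h; a higher number here means a weaker inhibitor, a lower number a stronger inhibitor. For the measured compounds named here, compound 1 `O=C1C(O)=C(C(c2ccc(Cl)cc2)c2c[nH]c3ccccc23)C(=O)c2ccccc21` gives 45800 nM and compound 2 `COc1cccc(C(C2=C(O)C(=O)c3ccccc3C2=O)c2c[nH]c3ccccc23)c1` gives 40000 nM; the step of a 1.1-fold lower number from compound 1 to compound 2 (0.06 log units; within the scatter) is the only measured single-change step in the set. Compound 3 `O=C1C(O)=C(C(c2cccc([N+](=O)[O-])c2)c2c(-c3ccccc3)[nH]c3ccccc23)C(=O)c2ccccc21` gives 5830 nM, the lowest of the three numbers, beyond the scatter from both compound 2 and compound 1. Compound 4 `O=C1C(O)=C(C(c2cccc([N+](=O)[O-])c2)c2c[nH]c3ccccc23)C(=O)c2ccccc21` is not yet measured. It differs from compound 3 by hydrogen in place of phenyl on an aromatic carbon. Going by the values given here, no measured pair isolates this change: compound 3 differs from compound 1 and from compound 2 in two places, the aryl group and the phenyl, so the gap between compound 3 and the other two cannot be split between them from the data. Among the compounds with values here, the one known step, an aryl exchange that leaves the number within the scatter, gives some reason to expect the removal of the phenyl to carry the larger share of that gap. On that basis compound 4 is expected to show a step of a 4.3-fold higher number from compound 3 to compound 4 (0.63 log units; beyond the scatter), with wide uncertainty. The estimate for compound 4 is 25000 nM, with a range from 8000 nM to 60000 nM.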

Compound 4, half-maximal inhibitory concentration: 36200 nM
Compound 4: middle estimate off by 1.4-fold (0.16 log units), on the low side; measured number inside the range.
By their numbers in this assay, from the lowest: compound 3; then compounds 4, 2 and 1 (each within the scatter of the next).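

In this assay the phenyl on the aromatic carbon next to the ring nitrogen is now isolated as a single change, and hydrogen in its place gives a step beyond the scatter (a 6.2-fold higher number from compound 3 to compound 4 (0.79 log units; beyond the scatter)). With hydrogen at this position, the aryl exchanges stay within the scatter, both for nitro in place of methoxy on an aromatic carbon (a 1.1-fold lower number from compound 2 to compound 4 (0.04 log units; within the scatter)) and for 3-nitrophenyl in place of 4-chlorophenyl (a 1.3-fold lower number from compound 1 to compound 4 (0.10 log units; within the scatter)), so among these compounds the phenyl step alone lies beyond the scatter. Nothing available explains the phenyl step.

Going by these compounds, the phenyl step can be read only with the 3-nitrophenyl group in place, so whether it carries over to the 4-chlorophenyl and 3-methoxyphenyl members remains open. The compounds shown also do not tell whether a methyl, a benzyl or a pyridyl group on that aromatic carbon would keep the number of compound 3 or fall back to that of compound 4.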